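A few compounds are considered here, and "the series" means these few. Any claim that something is new, unique, unknown or untested is made for them only; others in the source may bear on it.

The measured compounds in an assay on isolated protein for binding affinity to Melanocortin receptor 4 (Homo sapiens); a higher number here means a weaker inhibitor, a lower number a stronger inhibitor:

Compound 1 `CS(=O)(=O)N(CC1CC1)c1ccccc1N1CCN(C(=O)[C@H](CC(=O)N2CCN(CC3CC3)CC2)Cc2ccc(Cl)cc2)CC1` gives 3 nM.
Compound 2 `CC(=O)N1CCN(C(=O)C[C@H](Cc2ccc(Cl)cc2)C(=O)N2CCN(c3ccccc3N(CC3CC3)S(C)(=O)=O)CC2)CC1` gives 11 nM.
Compound 3 `CS(=O)(=O)N(CC1CC1)c1ccccc1N1CCN(C(=O)[C@H](CC(=O)N2CCN(C(=O)c3ccccc3)CC2)Cc2ccc(Cl)cc2)CC1` gives 4.4 nM.

Compound 1 has the lowest number of the three, though compound 3 sits within the scatter of it; only the gap to compound 2 is beyond the scatter. Compound 4 `CC(C)(C)CC(=O)N1CCN(C(=O)C[C@H](Cc2ccc(Cl)cc2)C(=O)N2CCN(c3ccccc3N(CC3CC3)S(C)(=O)=O)CC2)CC1` differs from compound 1 in one place: neopentylcarbonyl in place of cyclopropylmethyl on an amine nitrogen in a ring. Within the data shown here, two measured steps bear directly on this change, since each replaces the same cyclopropylmethyl with a group carrying a carbonyl. In this assay the step of a 3.7-fold higher number from compound 1 to compound 2 (0.56 log units; beyond the scatter) is modest and beyond the scatter, whereas a 1.5-fold higher number from compound 1 to compound 3 (0.17 log units; within the scatter) stays within it. The step of a 2.5-fold lower number from compound 2 to compound 3 (0.40 log units; beyond the scatter) shows that, of the two carbonyl-bearing groups, the one with phenyl on the carbonyl carbon gave the lower number. Neopentylcarbonyl shares the carbonyl with both, carries no ring unlike benzoyl, and is not as small as acetyl, so the nearest precedents point to a small to modest rise in the number rather than a large one. Compound 4 is therefore expected to give 6 nM (range 3 nM to 15 nM), a step estimated as a 2.0-fold higher number from compound 1 to compound 4 (0.30 log units; within the scatter).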

Compound 4, half-maximal inhibitory concentration: < 0.1 nM
Compound 4: a limit, no number; the forecaster's own chance of this, stated with the estimate: 2%; middle value at least 60-fold (1.77 log units) away from the limit.
By their numbers in this assay, from the lowest: compounds 1 and 3 (each within the scatter of the next); then compound 2. At a limit, below all of these: compound 4.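

In this assay compound 4 gives < 0.1 nM, which is a limit of the assay and not a number: the limit of < 0.1 nM in this assay, at which 1 of the 4 values shown sits.

Among these compounds, the ring nitrogen proved far more sensitive to its substituent than the earlier compounds suggested, with an at least 30-fold lower number from compound 1 to compound 4 (1.47 log units; beyond the scatter), whereas those compounds had stayed close together. The carbonyl alone does not explain the change, as acetyl and benzoyl carry it too, yet the group on the carbonyl carbon matters greatly, with an at least 110-fold lower number from compound 2 to compound 4 (2.04 log units; beyond the scatter) and an at least 44-fold lower number from compound 3 to compound 4 (1.64 log units; beyond the scatter).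

The compounds shown leave open how much of this step depends on the branched tert-butyl end and how much on chain length, a question that a straight pentyl chain or an isopropyl group on the carbonyl carbon would address, while a neopentyl group placed directly on the ring nitrogen would test the need for the carbonyl. Going by these compounds, the true value of compound 4 also remains unknown, so the full size of all three steps stays open.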